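The source may report more compounds than this note shows. Statements on the series, on what has been measured and on what is new or still open speak of the compounds shown alone.

Two measured compounds share one core and differ only in where the ester arm sits on it. Compound 1 `CCOC(=O)c1cccc(-c2ccc(OCC)cc2)n1` and compound 2 `CCOC(=O)c1cccc(-c2ccc(OCC)cc2)c1` were both tested in an assay on COS-7 cells for inhibition of patatin-like phospholipase domain-containing protein 2 (Mus musculus), tested at 200 uM; a higher number here means more inhibition at the concentration tested (going by the name of the read-out), a lower number less inhibition. In that assay compound 1 gives 79%, while compound 2 gives 87%. Compound 2 therefore has the higher of the two figures, but the gap to compound 1 lies within the usual scatter of such measurements, so the two cannot really be told apart.

The next compound, compound 3 `CCOC(=O)c1cccc(-c2ccc([N+](=O)[O-])cc2)c1`, keeps the core of compound 2 and changes one group on the outer ring: nitro in place of ethoxy on an aromatic carbon. Among the compounds with values here, no pair of measured compounds shows this particular exchange, so there is no measured step to lean on. Without such a guide, the expected step is modest, and a small loss of inhibition from compound 2 to compound 3 is estimated at a number 12 percentage points lower from compound 2 to compound 3 (beyond the scatter), a change that may well stay within the scatter. On that basis compound 3 is expected to give about 75% in this assay, with a plausible range from 50% to 95%.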

Compound 3, a percentage reported as inhibition, at one concentration (the size of the read-out at that concentration, not a potency): 63%
Beside the measured number, compound 3's estimate is 12 percentage points above it; low and high end bracket the measured number.
By their numbers in this assay, from the lowest: compound 3; then compounds 1 and 2 (each within the scatter of the next).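

Placing nitro in place of ethoxy on the outer ring, para to a large group, gives a number 24 percentage points lower from compound 2 to compound 3 (beyond the scatter) and is the first change here that moves the reading beyond the scatter in this assay. Within the data shown here, the earlier pair, compound 1 and compound 2, differ in the core and stand within the scatter of each other, so this outer position is the only place so far where a change of group clearly registers, although compound 3 still gives 63% at the one concentration tested. This single exchange cannot show which feature of the two groups lies behind the step, and no measurement at hand bears on the reason.

From the compounds shown here alone, with only ethoxy and nitro at this position, it remains open whether the step reflects the arrival of nitro or the departure of ethoxy, and an amine, a methoxy group or a plain hydrogen there would help to separate the two. Also open, going by these compounds, are whether the same exchange on the core of compound 1 would give a step of similar size and how a carboxylic acid in place of the ethyl ester would read.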